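A few compounds are considered here, and "the series" means these few. Any claim that something is new, unique, unknown or untested is made for them only; others in the source may bear on it.

Compound 1, `CSCC[C@@H](NC(=O)[C@H]1CCC(=O)N1)C(=O)N1CCC[C@@H]1C(N)=O`, was tested in a functional assay on the whole organism for inhibition, with Rattus norvegicus as the target, at a dose of 80 mg/kg by the intravenous route (on this read-out lower numbers stand for less inhibition and higher numbers for more inhibition at the one dose given (going by the name of the read-out)), where compound 1 gives 40%. Going by the values given here, of the two compounds measured so far, compound 1 stands highest. Its nearest neighbour is compound 2, `CC[C@H](C)[C@H](NC(=O)[C@@H]1CCC(=O)N1)C(=O)N1CCC[C@H]1C(N)=O`, which in this assay gives 10%, a number that lies beyond the usual scatter below that of compound 1. Compound 3, `CC(C)(C)OC[C@@H](NC(=O)[C@H]1CCC(=O)N1)C(=O)N1CCC[C@@H]1C(N)=O`, has not yet been measured. It differs from compound 1 in one place: tert-butoxy in place of (methylsulfanyl)methyl on a saturated chain carbon, two bonds along the chain from an amide-type nitrogen and a carbonyl carbon. Among the compounds with values here, no measured pair of compounds shows this change, so nothing in the data tells how large its effect is. The step expected in this assay is a small downward one, likely within the scatter, and is written as a number 10 percentage points lower from compound 1 to compound 3 (within the scatter). On that basis compound 3 is estimated to give 30%, with a range from 5% to 60%.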

Compound 3, a percentage reported as inhibition, in the whole organism at one dose (the size of the read-out at that dose, not a potency): 0%
Beside the measured number, compound 3's estimate is 30 percentage points above it; the measured number lies below the stated range.
By their numbers in this assay, from the lowest: compounds 3 and 2 (each within the scatter of the next); then compound 1.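

In this assay, the saturated chain carbon two bonds along the chain from an amide-type nitrogen and a carbonyl carbon proves sensitive to the group it carries: tert-butoxy in place of (methylsulfanyl)methyl gives a large step (a number 40 percentage points lower from compound 1 to compound 3 (beyond the scatter)). Neither group has a ring or a net charge, and their hydrogen-bond donor and acceptor counts match, so these counts do not separate the two groups. No measurement available here accounts for the size of this step.

The heavy-atom count and the exchange of sulfur for oxygen change together in this one step, so the compounds shown cannot tell these two differences apart. Going by these compounds, it remains open whether methoxymethyl, isobutyl or an amine at this position would keep the number seen for compound 1.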